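A few compounds are considered here, and "the series" means these few. Any claim that something is new, unique, unknown or untested is made for them only; others in the source may bear on it.

Measured set in a functional assay on NCI-H460 cells (Homo sapiens) for cytotoxicity, read by MTT assay, with a stated time of 72 h; a higher number here means a weaker inhibitor, a lower number a stronger inhibitor:
Compound 1, `CCN(CC)Cc1ccc2nc(NC(=O)N/N=C/c3cn(Cc4ccccc4Cl)c4ccccc34)sc2c1`, gives 980 nM.
Compound 2, `CC1CCN(Cc2ccc3nc(NC(=O)N/N=C/c4cn(Cc5cccc(Cl)c5)c5ccccc45)sc3c2)CC1`, gives 280 nM.
Compound 3, `CCN(CC)Cc1ccc2nc(NC(=O)N/N=C/c3cn(Cc4ccc(C)cc4)c4ccccc34)sc2c1`, gives 320 nM.

Compound 2 holds the lowest number of the three, but compound 3 lies within the scatter of it; only compound 1 stands clearly higher. The unmeasured compound 4, `CC1CCN(Cc2ccc3nc(NC(=O)N/N=C/c4cn(Cc5ccc(C(C)(C)C)cc5)c5ccccc45)sc3c2)CC1`, carries 4-(tert-butyl)phenyl in place of 3-chlorophenyl on a saturated chain carbon bound to an aromatic nitrogen. Within the data shown here, the one measured step that bears on this is a 3.1-fold lower number from compound 1 to compound 3 (0.49 log units; beyond the scatter), which likewise exchanges a chlorophenyl for an alkyl-bearing phenyl on the same kind of carbon, though with a different chlorophenyl and a different alkyl group than here. On that single precedent a small downward step is expected for compound 4, a 1.4-fold lower number from compound 2 to compound 4 (0.15 log units; within the scatter), with low confidence. Compound 4 is estimated at 200 nM, range 70 nM to 600 nM.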

Compound 4, half-maximal inhibitory concentration: 3370 nM
Compound 4: the middle estimate sits 17-fold (1.23 log units) below what was measured, and the stated range ends below it.
By their numbers in this assay, from the lowest: compounds 2 and 3 (each within the scatter of the next); then compound 1; then compound 4.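

At the saturated chain carbon bound to an aromatic nitrogen, exchanging a chlorophenyl for an alkyl-bearing phenyl does not always lower the number: in this assay, 3-chlorobenzyl to 4-(tert-butyl)benzyl gives a 12-fold higher number from compound 2 to compound 4 (1.08 log units; beyond the scatter), a step opposite in direction to a 3.1-fold lower number from compound 1 to compound 3 (0.49 log units; beyond the scatter) and larger. This exchange therefore has no single direction across these two pairs. Nothing available accounts for the rise.

Compound 3 and compound 4 differ in more than one place, so their alkyl groups cannot be compared directly. From the compounds shown here alone, whether the rise follows the loss of chlorine or the entry of tert-butyl stays open, and a plain benzyl group at this position would help separate the two.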